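Series at the assay limit: fluoro to trifluoromethoxy

The source may hold more compounds than are shown below. What is called first, only, known or untested is meant among the compounds shown, and "the series" means these compounds.

Values in an ADME assay on Raji cells (Homo sapiens) for cytotoxicity, with a stated time of 72 h (a lower number here means that less compound is needed, a higher number that more compound is needed for the effect), each one a limit and not a number
- compound 1 `Cc1cc(NC(=O)Nc2ccccc2N)c2ccccc2n1` gives > 25000 nM
- compound 2 `Cc1cc(NC(=O)Nc2cccc(F)c2)c2ccccc2n1` gives > 25000 nM
- compound 3 `COc1ccc(NC(=O)Nc2cc(C)nc3ccccc23)cc1F` gives > 25000 nM

Compound 2 gives > 25000 nM, which is a limit. It shares this position with the other two compounds, the series showing (the limit of > 25000 nM in this assay, at which 3 of the 3 values shown sit). Compound 4 `Cc1cc(NC(=O)Nc2cccc(OC(F)(F)F)c2)c2ccccc2n1` carries trifluoromethoxy in place of fluoro on an aromatic carbon. Among the compounds with values here, two measured steps bear on this change, a step that the two limits leave unreadable from compound 1 to compound 2 and a step that the two limits leave unreadable from compound 2 to compound 3, and neither gives a size. No step beyond the scatter is therefore expected in this assay, in either direction, and a further limit is the likely report. The expected change is a number no higher from compound 2 to compound 4 (the limit leaves the size open). For compound 4 the estimate is 25000 nM, with an expected range of 10000 nM to 50000 nM.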

Compound 4, half-maximal effective concentration: 9000 nM
Estimate against measurement, compound 4: 2.8-fold (0.44 log units) above; measured number outside the range, below it.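

In this assay, within the data shown here, trifluoromethoxy in place of fluoro on this aromatic carbon gives an at least 2.7-fold lower number from compound 2 to compound 4 (0.44 log units; beyond the scatter), the first readable step. Among these compounds, the earlier steps cannot be read, so this is the first sign that a change at this position can move the read-out. Compound 4 alone gives a number, while the other values remain limits: the limit of > 25000 nM in this assay, at which 3 of the 4 values shown sit.

Going by these compounds, the full size of the step stays open. Also open, on these data alone, is whether trifluoromethyl, chloro or an amine on this carbon would bring the number under the limit.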